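The source may report more compounds than this note shows. Statements on the series, on what has been measured and on what is new or still open speak of the compounds shown alone.

Compound 3 `Cc1cc(S(=O)(=O)/N=C(\N)n2nccc2-c2ccccc2)c(SCc2ccc(C(F)(F)F)cc2)cc1Cl` gives 0.176 h in an ADME assay on microsomes from liver (Homo sapiens) for metabolic stability, read by LC-MS, using NADPH, tested at 5 uM (a lower number here means that the compound disappears faster, a higher number that the compound lasts longer), the lowest number of the three measured compounds, although neither of the other two lies beyond the scatter of it. Compound 2 `Cc1cccc(CSc2cc(Cl)c(C)cc2S(=O)(=O)/N=C(\N)n2nc(C)cc2-c2ccccc2)c1` gives 0.214 h in this assay, and compound 1 `Cc1cc(-c2ccccc2)n(/C(N)=N/S(=O)(=O)c2cc(C)c(Cl)cc2SCc2ccc(C(F)(F)F)cc2)n1` gives 0.241 h; the step of a 1.4-fold lower number from compound 1 to compound 3 (0.14 log units; within the scatter) describes the distance between compound 1 and compound 3.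

Compound 4 `Cc1cc(S(=O)(=O)/N=C(\N)n2nccc2-c2ccccc2)c(SCc2ccccc2C(F)(F)F)cc1Cl` differs from compound 3 only in 2-(trifluoromethyl)phenyl in place of 4-(trifluoromethyl)phenyl on a saturated chain carbon bound to a sulfur. Among the measured compounds shown here, one measured step bears directly on this position: the step of a 1.1-fold lower number from compound 1 to compound 2 (0.05 log units; within the scatter), which exchanged one aryl group for another on the same saturated chain carbon bound to a sulfur and did not move the number beyond the scatter. The step of a 1.4-fold lower number from compound 1 to compound 3 (0.14 log units; within the scatter) on the shared core was likewise within the scatter. For the measured compounds named here, nothing among the measured compounds tests a trifluoromethyl moved from the 4-position to the 2-position of that phenyl, so the rearrangement itself carries no measured precedent.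

On this basis the step of a 1.0-fold higher number from compound 3 to compound 4 (0.01 log units; within the scatter) is expected to stay within the scatter. Compound 4 is therefore estimated to give 0.18 h in this assay, with a likely range from 0.1 h to 0.32 h.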

Compound 4, half-life: 0.15 h
Beside the measured number, compound 4's estimate is 1.2-fold (0.08 log units) above it; measured number inside the range.
By their numbers in this assay, from the lowest: compounds 4, 3, 2 and 1 (each within the scatter of the next).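

Among the compounds shown here, replacing 4-(trifluoromethyl)phenyl with 2-(trifluoromethyl)phenyl on a saturated chain carbon bound to a sulfur gives, in this assay, a 1.2-fold lower number from compound 3 to compound 4 (0.07 log units; within the scatter), which is the first measured test of where the trifluoromethyl stands on that phenyl. Together with a 1.1-fold lower number from compound 1 to compound 2 (0.05 log units; within the scatter), which exchanged 4-(trifluoromethyl)phenyl for 3-methylphenyl, this means that both aryl exchanges shown at this position stay within the scatter, and neither compound pair goes against that reading, although two steps on two different cores make only a narrow pattern. No measured evidence is available to explain this result.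

The compounds shown carry only substituted phenyl groups on this chain carbon, so it remains open whether a pyridine ring, an aryl group bearing a carboxylic acid or an amine, or a longer chain between the sulfur and the phenyl would move the number beyond the scatter. Going by these compounds, it is also open whether 2-(trifluoromethyl)phenyl would behave in the same way on the core of compound 1, which carries a methyl where compound 4 has hydrogen.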